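Swapping the amine tail of a weakly active coumarin

A few compounds are considered here, and "the series" means these few. Any claim that something is new, unique, unknown or untested is made for them only; others in the source may bear on it.

Compound 1 `COc1cc2ccc(=O)oc2cc1OCC(O)CN1CCN(C)CC1`: 3.4%
Compound 2 `COc1cc2ccc(=O)oc2cc1OCC(=O)c1ccc([N+](=O)[O-])cc1`: 27.2%
Compound 3 `COc1cc2ccc(=O)oc2cc1OCC(=O)c1ccccc1`: 83.6%

In a functional assay on HUVEC cells (Homo sapiens) for inhibition, read by MTT assay, with a stated time of 24 h, tested at 100 uM (a higher number here means more inhibition of growth at the concentration tested, a lower number less inhibition of growth), compound 1 gives 3.4%, the lowest of the three numbers. Compound 2 sits a number 27.2% higher, beyond the scatter, and compound 3 stands furthest away at 83.6%, also beyond the scatter.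

Compound 4 `CCN(CC)CC(O)COc1cc2oc(=O)ccc2cc1OC` differs from compound 1 in its amine tail: diethylamino in place of 4-methylpiperazin-1-yl on a saturated chain carbon, two bonds along the chain from an oxygen on a saturated carbon. For the measured compounds named here, the only measured step, a number 56.4 percentage points higher from compound 2 to compound 3 (beyond the scatter), concerns a different change on an aromatic ring and does not bear on this one. Going by the values given here, there is no measured step for swapping one amine for another, so the expected step in this assay is small, a number 4.6 percentage points higher from compound 1 to compound 4 (within the scatter), with no direction that can be trusted beyond the scatter. Compound 4 is therefore estimated at 8%, within a range from 0% to 25%.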

Compound 4, percent growth inhibition at one concentration: 0.3%
For compound 4 the middle estimate is 7.7 percentage points above the measured one, within the range that was stated.
By their numbers in this assay, from the lowest: compounds 4 and 1 (each within the scatter of the next); then compound 2; then compound 3.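

In this assay, diethylamino in place of 4-methylpiperazin-1-yl gives a number 3.1 percentage points lower from compound 1 to compound 4 (within the scatter), so the two amine tails cannot be told apart at this position. Losing the six-membered ring and one of the two nitrogens therefore leaves no reading beyond the scatter, and both compounds stay close to the bottom of the series. No measurement shown explains this result. Going by these compounds, what remains open is whether a morpholine or a primary amine at this chain carbon would read differently, and whether a longer chain carrying the same amines would do so.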